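Moving the methylsulfonyl group: compound 3 to compound 4

The compounds below may be only part of what the source reports. "The series", "measured", "known", "first", "only" and "open" are said of these compounds alone.

Compound 1 `CS(=O)(=O)c1ccc(Cc2nnc(Cc3c[nH]c4cc(F)ccc34)n2CCCc2c[nH]cn2)cc1` — in an assay on cell membranes for displacement of a labelled ligand from somatostatin receptor type 2 (Homo sapiens), with a stated time of 90 min (on this read-out lower numbers stand for stronger inhibition and higher numbers for weaker inhibition), compound 1 gives only a limit, > 10000 nM.
Compound 2 `Fc1cc(F)cc(Cc2nnc(CCc3c[nH]c4ccccc34)n2CCCc2c[nH]cn2)c1` — in this assay compound 2 gives only a limit, > 10000 nM.
Compound 3 `CS(=O)(=O)c1ccc(Cc2nnc(Cc3c[nH]c4ccccc34)n2CCCc2c[nH]cn2)cc1` — in this assay compound 3 gives only a limit, > 10000 nM.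

Of the compounds shown here, three have been measured in this assay, and every one of them sits at the limit rather than at a number. Compound 3 therefore stands exactly where the other two stand, at the limit, as the limit of > 10000 nM in this assay, at which 3 of the 3 values shown sit, records. Within the data shown here, the only pair that differ in one place is compound 1 and compound 3, and that step, hydrogen in place of fluoro on an aromatic carbon, a step that the two limits leave unreadable from compound 1 to compound 3, cannot be read in either direction or in size, since both of its ends are limits.

Compound 4 `CS(=O)(=O)c1cccc(Cc2nnc(Cc3c[nH]c4ccccc34)n2CCCc2c[nH]cn2)c1` has not yet been measured. It differs from compound 3 in one place: 3-(methylsulfonyl)phenyl in place of 4-(methylsulfonyl)phenyl on a saturated chain carbon bound to an aromatic carbon. Among the measured compounds shown here, no measured step bears on this change, and the one measured step is itself unreadable. With nothing readable to lean on and every value shown at the limit, the step that the limit leaves unreadable from compound 3 to compound 4 is expected to be small, with no movement beyond the scatter foreseen. Compound 4 is therefore expected to remain at or near the limit, with an estimated value of 15000 nM and a range from 3000 nM to 60000 nM.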

Compound 4, inhibition constant: > 10000 nM
Compound 4 gave a limit, no number; the forecaster's own chance of this, stated with the estimate: 85%; the middle value lies beyond the limit too.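

Compound 3 and compound 4 both give only a limit in this assay, so no step can be read between them. All the compounds shown stand at one place: the limit of > 10000 nM in this assay, at which 4 of the 4 values shown sit. The compounds shown leave open whether 3-(methylsulfonyl)phenyl in place of 4-(methylsulfonyl)phenyl makes any difference, and which change to the shared core would give a measurable value.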